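Furan-2-yl in place of 4-fluorophenyl on the benzamide

A few compounds are considered here, and "the series" means these few. Any claim that something is new, unique, unknown or untested is made for them only; others in the source may bear on it.

Of the compounds shown here, three sharing one core have been tested in a functional assay on Raji cells (Homo sapiens) for antiproliferative activity, read by CCK-8 assay, with a stated time of 72 h, tested at 40 uM; a higher number here means more inhibition at the concentration tested (going by the name of the read-out), a lower number less inhibition. Compound 1 `CCOC(=O)c1sc(-c2cccc(NC(=O)c3ccc(F)cc3)c2)nc1Nc1ccc(N2CCN(C)CC2)cc1` gives 16.8%. Compound 2 `CN1CCN(c2ccc(Nc3nc(-c4cccc(NC(=O)c5ccc(F)c(Cl)c5)c4)sc3C(=O)O)cc2)CC1` gives 87.9%. Compound 3 `CN1CCN(c2ccc(Nc3nc(-c4cccc(NC(=O)c5ccc(F)cc5)c4)sc3C(N)=O)cc2)CC1` gives 95.3%, the highest of the three numbers; it lies within the scatter of compound 2 and far beyond the scatter of compound 1. Within the data shown here, the only step between compounds differing in one place is a number 78.5 percentage points higher from compound 1 to compound 3 (beyond the scatter), where amino replaces ethoxy on a carbonyl carbon.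

Compound 4 `CN1CCN(c2ccc(Nc3nc(-c4cccc(NC(=O)c5ccco5)c4)sc3C(N)=O)cc2)CC1` differs from compound 3 in a different place: furan-2-yl in place of 4-fluorophenyl on a carbonyl carbon. Among the measured compounds shown here, no measured step bears on this change, since the one known step concerns the group on the other carbonyl carbon, and the benzamide part of compound 2 differs from compound 3 at the ring while compound 2 also carries a different group on the first carbonyl carbon. Compound 3 sits near the top of the scale, so the estimate for compound 4 is a number 10.3 percentage points lower from compound 3 to compound 4 (beyond the scatter), expected to stay high. The expected value for compound 4 in this assay is 85%, with a range from 60% to 98%.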

Compound 4, a percentage reported as inhibition, at one concentration (the size of the read-out at that concentration, not a potency): 84.3%
Compound 4: the middle estimate sits 0.7 percentage points above what was measured, and the stated range covers the measured number.
By their numbers in this assay, from the lowest: compound 1; then compounds 4, 2 and 3 (each within the scatter of the next, the first and the last beyond it).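

Among these compounds, replacing 4-fluorophenyl with furan-2-yl on the carbonyl carbon gives the first reading of a single change at this position in this assay: a number 11 percentage points lower from compound 3 to compound 4 (beyond the scatter). The position therefore responds to the group it carries, yet the step is modest beside a number 78.5 percentage points higher from compound 1 to compound 3 (beyond the scatter), and compound 4 still gives 84.3%, so a five-membered aromatic ring with one hetero atom keeps most of the inhibition seen at this concentration. Nothing available explains why the number falls with this change.

This single step cannot separate the change in ring size, the loss of fluorine and the entry of the ring oxygen. The compounds shown leave open how plain phenyl, thienyl or pyridyl would read here, and whether the furan-2-yl step would hold with ethoxy on the other carbonyl carbon.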